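A few compounds are considered here, and "the series" means these few. Any claim that something is new, unique, unknown or untested is made for them only; others in the source may bear on it.

Measured compounds:
- compound 1, `CCCn1cnc2c(NCc3ccccc3)ncnc21`, in an assay on CHO cells for displacement of a labelled ligand from transmembrane domain-containing protein TMIGD3 (Homo sapiens) (a lower number here means a stronger inhibitor, a higher number a weaker inhibitor), compound 1 gives 29100 nM
- compound 2, `CCCn1cnc2c(NCCCc3ccccc3)ncnc21`, in this assay compound 2 gives 30000 nM

Compound 2 has the higher of the two numbers in this assay, but the two values for compound 1 and compound 2 lie within the scatter of each other, so neither is set apart; both are weak binders.

Compound 3, `CCCn1c(-c2ccco2)nc2c(NCCCc3ccccc3)ncnc21`, takes the step from compound 2 in one place: furan-2-yl in place of hydrogen on an aromatic carbon. Among the compounds with values here, no measured pair shows what this kind of change does in this assay, so the direction of the step cannot be read from the data. A moderate change in either direction is plausible; a gain in potency is taken as slightly more likely, and compound 3 is expected to give 15000 nM, with a range from 4000 nM to 60000 nM. The step this estimate means, a 2.0-fold lower number from compound 2 to compound 3 (0.30 log units; within the scatter), is thus expected to be modest.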

Compound 3, inhibition constant: 959 nM
Estimate against measurement, compound 3: 16-fold (1.19 log units) above; measured number outside the range, below it.
By their numbers in this assay, from the lowest: compound 3; then compounds 1 and 2 (each within the scatter of the next).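

The aromatic carbon between two ring nitrogen atoms, next to the ring atom that bears a propyl group, proves to be a sensitive place in the series: in this assay, furan-2-yl in place of hydrogen gives a 31-fold lower number from compound 2 to compound 3 (1.50 log units; beyond the scatter). Within the data shown here, neither compound 1 nor compound 2 carries a group on this carbon, so this is the first sign that a substituent here is accepted and that it can lift a weak binder well clear of the scatter. The compounds shown offer no data that explain the size of this step.

Going by these compounds, whether the gain needs furan-2-yl itself stays open, since a thiophen-2-yl or a methyl group on the same carbon could give a smaller or a similar step. On these data alone, it is also open whether furan-2-yl at this place would give a like step on compound 1.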